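Adding a Third Methoxy Group to an Amide Analogue

The source may report more compounds than this note shows. Statements on the series, on what has been measured and on what is new or still open speak of the compounds shown alone.

Compound 1, `COc1ccc(C(=O)/C=C/c2ccccc2-c2ccc(F)cc2)cc1OC`, and compound 2, `COc1cc(C(=O)/C=C/c2ccccc2-c2ccc(F)cc2)cc(OC)c1OC`, share a core and differ in a single place: methoxy in place of hydrogen on an aromatic carbon. In a functional assay on SW480 cells (Homo sapiens) for antiproliferative activity, read by sulforhodamine B assay, with a stated time of 48 h (on this read-out lower numbers stand for stronger inhibition and higher numbers for weaker inhibition), compound 1 gives 8300 nM, while compound 2 gives 2200 nM, so the added methoxy group brought a 3.8-fold lower number from compound 1 to compound 2 (0.58 log units; beyond the scatter).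

Compound 3, `COc1ccc(CNC(=O)c2ccccc2-c2ccc(F)cc2)cc1OC`, carries a different core in which an amide linker takes the place of the unsaturated ketone of compound 1; the difference between the two cores is not broken down here. In this assay compound 3 gives only a limit, > 50000 nM, and not a number. One of the three measured values sits at the limit of > 50000 nM in this assay, at which 1 of the 3 values shown sits.

Compound 4, `COc1cc(CNC(=O)c2ccccc2-c2ccc(F)cc2)cc(OC)c1OC`, has not been measured. Among the measured compounds shown here, it differs from compound 3 by methoxy in place of hydrogen on an aromatic carbon, which is the same change, in the same surroundings, as the one from compound 1 to compound 2. If that change behaves alike on the amide core, compound 4 is expected to improve on compound 3 by roughly an at least 1.2-fold lower number from compound 3 to compound 4 (0.09 log units; that floor lies within the scatter), resting on the step seen from compound 1 to compound 2 of a 3.8-fold lower number from compound 1 to compound 2 (0.58 log units; beyond the scatter). Since compound 3 is known only as a limit, the starting point for that step is itself uncertain, and a limit is a real possibility for compound 4 as well. On that basis compound 4 in this assay is estimated at 40000 nM, expected to fall between 12000 nM and 150000 nM.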

Compound 4, half-maximal inhibitory concentration: > 50000 nM
Compound 4 was reported as a limit; the forecaster's own chance of this, stated with the estimate: 55%; middle value at least 1.2-fold (0.09 log units) away from the limit.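

In this assay compound 4 gives > 50000 nM, which is a limit of the assay and not a number. Compound 3 carries a limit too, and no step between compound 3 and compound 4 can be read: the limit of > 50000 nM in this assay, at which 2 of the 4 values shown sit.

The compounds shown leave open whether methoxy in place of hydrogen on an aromatic carbon changes the activity at all on the amide core of compound 3.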